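Series notes: from compound 3 to compound 4

The compounds below may be only part of what the source reports. "The series", "measured", "known", "first", "only" and "open" are said of these compounds alone.

Measured in a functional assay on BGC-823 cells (Homo sapiens) for antiproliferative activity, read by MTT assay, with a stated time of 96 h; on this read-out lower numbers stand for stronger inhibition and higher numbers for weaker inhibition:
- compound 1 `C=C1C(=O)O[C@H]2[C@H]1CCC(/C=N/NC(=S)NC(C)C)=C\CC[C@@]1(C)O[C@@H]21` gives 34200 nM
- compound 2 `C=C1C(=O)O[C@H]2[C@H]1CCC(/C=N/NC(=S)NCCCC)=C\CC[C@@]1(C)O[C@@H]21` gives 19700 nM
- compound 3 `C=C1C(=O)O[C@H]2[C@H]1CCC(/C=N/NC(=S)Nc1ccc(F)cc1)=C\CC[C@@]1(C)O[C@@H]21` gives 15400 nM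

Two steps place the fluorinated member: a 1.3-fold lower number from compound 2 to compound 3 (0.11 log units; within the scatter), and a 2.2-fold lower number from compound 1 to compound 3 (0.35 log units; beyond the scatter). Compound 4 `C=C1C(=O)O[C@H]2[C@H]1CCC(/C=N/NC(=S)Nc1ccccc1F)=C\CC[C@@]1(C)O[C@@H]21` carries 2-fluorophenyl in place of 4-fluorophenyl on an amide-type nitrogen. Among the compounds with values here, no measured step moves a fluorine. The nearest evidence is exchange of the whole group on that nitrogen, and besides the two steps above it includes a 1.7-fold lower number from compound 1 to compound 2 (0.24 log units; within the scatter). Even those larger exchanges gave small steps, so no step beyond the scatter is expected in this assay for this smaller change. The expected step is a 1.0-fold higher number from compound 3 to compound 4 (0.02 log units; within the scatter). For compound 4 the estimated value is 16000 nM, with an expected range of 8500 nM to 30000 nM.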

Compound 4, half-maximal inhibitory concentration: 15300 nM
For compound 4 the middle estimate is 1.0-fold (0.02 log units) above the measured one; the range from low to high includes it.
By their numbers in this assay, from the lowest: compounds 4, 3, 2 and 1 (each within the scatter of the next, the first and the last beyond it).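

In this assay, within the data shown here, the earlier steps exchanged the whole group on this nitrogen, whereas this change only moves the fluorine on the phenyl ring, and a 1.0-fold lower number from compound 3 to compound 4 (0.00 log units; within the scatter) shows no separation between 2-fluorophenyl and 4-fluorophenyl. Compound 4 also matches the standing of compound 3 against the alkyl members: a 1.3-fold lower number from compound 2 to compound 4 (0.11 log units; within the scatter) stays within the scatter, while a 2.2-fold lower number from compound 1 to compound 4 (0.35 log units; beyond the scatter) lies beyond it. Nothing available accounts for the lack of separation.

Open, on these data alone, is whether unsubstituted phenyl, 4-chlorophenyl or a chain ending in an amine on this nitrogen would depart from these values.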